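The source may report more compounds than this note shows. Statements on the series, on what has been measured and on what is new or still open speak of the compounds shown alone.

Four compounds are compared here, all sharing a ring bearing an amide and a hydroxylated phenyl group, and all tested in an ADME assay on MRC5 cells (Homo sapiens) for cytotoxicity, read by MTT assay, with a stated time of 72 h; on this read-out higher numbers stand for weaker inhibition and lower numbers for stronger inhibition. Compound 1 is `O=C(Nc1nnc(-c2cccc(O)c2O)s1)c1ccccc1`, compound 2 is `CC(=O)Nc1nnc(-c2cccc(O)c2O)s1`, compound 3 is `CC(=O)Nc1nnc(-c2ccc(O)c(O)c2)s1`, and compound 4, not yet measured, is `O=C(Nc1nnc(-c2ccc(O)c(O)c2)s1)c1ccccc1`.

In this assay compound 2 gives 156000 nM, and compound 1 gives 23200 nM. The change between them is phenyl in place of methyl on a carbonyl carbon. That single change produced a 6.7-fold lower number from compound 2 to compound 1 (0.83 log units; beyond the scatter), a clear shift towards stronger inhibition of cell growth.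

Compound 3 differs from compound 2 in its core, and the difference between the two cores is not broken down here. In this assay compound 3 gives 58600 nM, which places it between the other two measured compounds.

Compound 4 stands to compound 3 as compound 1 stands to compound 2: the change is phenyl in place of methyl on a carbonyl carbon. Because the earlier step gave a 6.7-fold lower number from compound 2 to compound 1 (0.83 log units; beyond the scatter), the expected outcome is that the same kind of change on the core of compound 3 lowers the number by a comparable amount, so the step is estimated as a 5.9-fold lower number from compound 3 to compound 4 (0.77 log units; beyond the scatter). Among the compounds with values here, only one earlier example of this change exists, and it sits on a different core, so the range is kept fairly wide. The estimate for compound 4 is 10000 nM, with a likely range from 3500 nM to 30000 nM.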

Compound 4, half-maximal inhibitory concentration: 27400 nM
Compound 4: middle estimate off by 2.7-fold (0.44 log units), on the low side, and the stated range covers the measured number.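

In this assay, phenyl in place of methyl on a carbonyl carbon again lowers the number, with a 2.1-fold lower number from compound 3 to compound 4 (0.33 log units; beyond the scatter) pointing the same way as the earlier step, so the direction of the change holds on both cores shown. The size of the step does not carry over, however, and the gap between the two steps is larger than repeated measurements would be expected to produce: the same change on two cores in this assay, a 6.7-fold lower number (0.83 log units; beyond the scatter) from compound 2 to compound 1 and a 2.1-fold lower number (0.33 log units; beyond the scatter) from compound 3 to compound 4, 3.1-fold (0.50 log units) apart, beyond the scatter of two such steps. This shows that, in this series, a step measured on one core gives the direction on another core more safely than it gives the size, but two pairs of compounds cannot reveal which feature of the cores sets the size, or how the change would behave on a third core.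

The compounds shown leave open how other groups on the same carbonyl carbon, such as a longer chain like butyl or a ring-free amine, would compare with methyl and phenyl on each core. They also leave open whether the gap between the two steps would persist for such groups or is particular to the swap from methyl to phenyl.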